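From Fluoro to Methyl Without a Measured Starting Point

This account rests on a few compounds, and the source may have more. Where it says the series, first, only, none or still open, it means among the compounds named here.

In a functional assay on PANC-1 cells (Homo sapiens) for antiproliferative activity, read by MTT assay, with a stated time of 48 h (on this read-out higher numbers stand for weaker inhibition and lower numbers for stronger inhibition), compound 1 (`COc1ccc(-c2c(Nc3cc(OC)c(OC)c(OC)c3)c3ccccc3oc2=O)cc1`) gives 77600 nM and compound 2 (`COc1ccc(-c2c(Nc3ccc(F)cc3)c3ccccc3oc2=O)cc1`) gives 32000 nM. Compound 3 (`COc1ccc(-c2c(Nc3ccc(F)cc3)c3ccc(OC)cc3oc2=O)cc1`) offers no number to start from: in this assay, compound 3 stands at "not determined" (no result reported). Compound 4 (`COc1ccc(-c2c(Nc3ccc(C)cc3)c3ccc(OC)cc3oc2=O)cc1`) has not yet been measured. The structural change under consideration is methyl in place of fluoro on an aromatic carbon, which places methyl in place of fluoro on an aromatic carbon, para to a large group. Within the data shown here, no measured pair in this small set shows what such a swap does, and the starting value itself is missing. No step beyond the usual scatter is therefore expected in this assay, in either direction. The expectation leans on compound 2 at 32000 nM, the measured compound that also carries the 4-fluorophenyl group, and it remains loose. For compound 4 the estimated value is 35000 nM, with an expected range from 12000 nM to 90000 nM.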

Compound 4, half-maximal inhibitory concentration: 76500 nM
The estimate for compound 4 lay 2.2-fold (0.34 log units) below the measured number, within the range that was stated.
By their numbers in this assay, from the lowest: compound 2; then compounds 4 and 1 (each within the scatter of the next).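

Among these compounds, with no number for compound 3 in this assay, no step to compound 4 can be read. The compounds shown leave open what methyl in place of fluoro does to antiproliferative activity on this core. No supporting data bear on this result.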